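Aryl swap on a shared core: estimating compound 4

The compounds below may be only part of what the source reports. "The series", "measured", "known", "first", "only" and "open" are said of these compounds alone.

The measured compounds:
compound 1, `COc1cc2c(Oc3ccc(NC(=O)c4nn(-c5ccc(Br)cc5)c(=O)c5ccccc45)cc3F)ccnc2cc1OCCCN1CCN(C)CC1`, 250 nM
compound 2, `COc1cc2c(Oc3ccc(NC(=O)c4nn(-c5ccc(Br)cc5)c(=O)c5ccccc45)cc3F)ccnc2cc1OCCCN1CCCCC1`, 410 nM
compound 3, `COc1cc2c(Oc3ccc(NC(=O)c4nn(-c5cccc(F)c5)c(=O)c5ccccc45)cc3F)ccnc2cc1OCCCN1CCC(C)CC1`, 190 nM

These three share one core and were read in a functional assay on NCI-H460 cells (Homo sapiens) for cytotoxicity, read by MTT assay, with a stated time of 72 h; on this read-out lower numbers stand for stronger inhibition and higher numbers for weaker inhibition. Compound 3 gives the lowest number of the three in this assay; its gap to compound 1 lies within the scatter, and only its gap to compound 2 lies beyond it. For the measured compounds named here, the one measured single-point step, a 1.6-fold higher number from compound 1 to compound 2 (0.21 log units; within the scatter), concerns the chain amine and stays within the scatter.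

Compound 4 is `COc1cc2c(Oc3ccc(NC(=O)c4nn(-c5ccc(Br)cc5)c(=O)c5ccccc45)cc3F)ccnc2cc1OCCCN1CCC(C)CC1`. It differs from compound 3 in one place: 4-bromophenyl in place of 3-fluorophenyl on an aromatic nitrogen. Going by the values given here, no measured pair differs only at this aromatic nitrogen substituent, so no measured step bears on the change directly. Compounds 1 and 2, which carry the entering group with other chain amines, give numbers close to that of compound 3, which suggests a modest effect at most. Compound 4 is therefore expected to sit near compound 3 in this assay, with an estimated step of a 1.4-fold higher number from compound 3 to compound 4 (0.15 log units; within the scatter), giving an estimate of 270 nM, between 120 nM and 650 nM.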

Compound 4, half-maximal inhibitory concentration: 350 nM
Compound 4: middle estimate off by 1.3-fold (0.11 log units), on the low side; low and high end bracket the measured number.
By their numbers in this assay, from the lowest: compounds 3, 1, 4 and 2 (each within the scatter of the next, the first and the last beyond it).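

In this assay, the exchange of 3-fluorophenyl for 4-bromophenyl on the aromatic nitrogen now has a measured step of its own, a 1.8-fold higher number from compound 3 to compound 4 (0.27 log units; within the scatter), and this step stays within the scatter for this pair of groups. With 4-bromophenyl in place, the chain amine also stays within the scatter: methyl in place of hydrogen on a saturated ring carbon gives a 1.2-fold lower number from compound 2 to compound 4 (0.07 log units; within the scatter), and 4-methylpiperidin-1-yl in place of 4-methylpiperazin-1-yl gives a 1.4-fold higher number from compound 1 to compound 4 (0.15 log units; within the scatter). No evidence is available to account for any of these steps.

On these data alone, whether a group of another kind on the aromatic nitrogen, such as a pyridyl ring, 4-methoxyphenyl or plain methyl, would move the number beyond the scatter remains open. As far as these compounds go, it is also open whether a morpholine at the end of the chain would do so.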